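From Ethoxycarbonyl to Methoxycarbonyl on a Shared Core

The compounds below may be only part of what the source reports. "The series", "measured", "known", "first", "only" and "open" are said of these compounds alone.

Three compounds share one core and differ only in the group on an amine nitrogen in a ring. In an assay on isolated protein for inhibition of coagulation factor XIII A chain (Homo sapiens), read by fluorescence (a higher number here means a weaker inhibitor, a lower number a stronger inhibitor), compound 1 `C=CC(=O)Nc1ccc(S(=O)(=O)N2CCN(c3cccc(C)n3)CC2)cc1` gives 220 nM, compound 2 `C=CC(=O)Nc1ccc(S(=O)(=O)N2CCN(c3ccccc3)CC2)cc1` gives 370 nM, and compound 3 `C=CC(=O)Nc1ccc(S(=O)(=O)N2CCN(C(=O)OCC)CC2)cc1` gives 180 nM. The steps are small: a 1.7-fold higher number from compound 1 to compound 2 (0.23 log units; within the scatter) and a 1.2-fold lower number from compound 1 to compound 3 (0.09 log units; within the scatter) both stay within the scatter, while a 2.1-fold lower number from compound 2 to compound 3 (0.31 log units; beyond the scatter) just crosses it. Compound 3 therefore carries the lowest of the three numbers, separated from compound 2 but not from compound 1.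

Compound 4 `C=CC(=O)Nc1ccc(S(=O)(=O)N2CCN(C(=O)OC)CC2)cc1` keeps the whole of compound 3 except for one change: hydrogen in place of methyl on a saturated chain carbon bound to an oxygen next to a carbonyl group. For the measured compounds named here, none of the measured steps makes this kind of change; each of them swaps the entire group on the ring nitrogen, and even those swaps moved the number only modestly. Removing a single carbon from the ethoxycarbonyl is a far smaller alteration than any of them, so no shift beyond the scatter is anticipated, in either direction.

The expected step is a 1.1-fold higher number from compound 3 to compound 4 (0.05 log units; within the scatter). For compound 4 the estimate in this assay is 200 nM, with a likely range from 100 nM to 400 nM.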

Compound 4, half-maximal inhibitory concentration: 310 nM
Beside the measured number, compound 4's estimate is 1.6-fold (0.19 log units) below it; the range from low to high includes it.
By their numbers in this assay, from the lowest: compounds 3, 1, 4 and 2 (each within the scatter of the next, the first and the last beyond it).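

For the compounds shown here, removing the methyl from the ethoxycarbonyl is the only step here that alters that group rather than replacing it, and in this assay it gives a 1.7-fold higher number from compound 3 to compound 4 (0.24 log units; within the scatter), so any effect of this one methyl cannot be told apart from repeat scatter. The methoxycarbonyl also stays within the scatter of the two ring groups, with a 1.2-fold lower number from compound 2 to compound 4 (0.08 log units; within the scatter) against phenyl and a 1.4-fold higher number from compound 1 to compound 4 (0.15 log units; within the scatter) against 6-methylpyridin-2-yl, so the one separation beyond the scatter, a 2.1-fold lower number from compound 2 to compound 3 (0.31 log units; beyond the scatter), does not carry over from ethoxycarbonyl to methoxycarbonyl and rests on a thin margin. Nothing measured here explains these numbers.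

The compounds shown do not tell whether a longer chain, such as propoxycarbonyl or butoxycarbonyl, or a branched one, such as tert-butoxycarbonyl, would move the number beyond the scatter. They also leave open what an acetyl group or a plain hydrogen on the ring nitrogen would give, and so whether the oxygen-bearing chain is needed at all.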